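This account rests on a few compounds, and the source may have more. Where it says the series, first, only, none or still open, it means among the compounds named here.

Compound 1 `CN(C(=O)C(C)(C)C)c1ccc2[nH]c(-c3n[nH]c4ccccc34)cc2n1`: 18000 nM
Compound 2 `CN(C(=O)CCc1ccccc1)c1ccc2[nH]c(-c3n[nH]c4ccccc34)cc2n1`: 11200 nM

Two compounds sharing one core were measured in a functional assay on HCT-116 cells (Homo sapiens) for antiproliferative activity, read by MTT assay, with a stated time of 72 h; on this read-out lower numbers stand for stronger inhibition and higher numbers for weaker inhibition. Compound 1 gives 18000 nM, and compound 2 gives 11200 nM. Going by the values given here, the only step between them, a 1.6-fold lower number from compound 1 to compound 2 (0.21 log units; within the scatter), lies within the scatter, so compound 2 has the lower of the two numbers without standing apart from compound 1.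

Compound 3 `CN(C(=O)c1ccc(F)cc1)c1ccc2[nH]c(-c3n[nH]c4ccccc34)cc2n1` is not yet measured. It differs from compound 2 by 4-fluorophenyl in place of phenethyl on a carbonyl carbon. Among the compounds with values here, the single measured step that touches the same carbonyl carbon, a 1.6-fold lower number from compound 1 to compound 2 (0.21 log units; within the scatter), stayed within the scatter, and no measured step involves a 4-fluorophenyl group at all. The account therefore expects for compound 3 no step beyond the scatter, an expected step of a 1.0-fold lower number from compound 2 to compound 3 (0.01 log units; within the scatter) in this assay. Compound 3 is estimated at 11000 nM, within an expected range from 4000 nM to 30000 nM.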

Compound 3, half-maximal inhibitory concentration: 9270 nM
Compound 3: the middle estimate sits 1.2-fold (0.07 log units) above what was measured, and the stated range covers the measured number.
By their numbers in this assay, from the lowest: compounds 3, 2 and 1 (each within the scatter of the next).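

In this assay, the 4-fluorophenyl group on the carbonyl carbon gives a 1.2-fold lower number from compound 2 to compound 3 (0.08 log units; within the scatter) and a 1.9-fold lower number from compound 1 to compound 3 (0.29 log units; within the scatter). With both steps within the scatter, the position now holds three groups, tert-butyl, phenethyl and 4-fluorophenyl, and an aromatic ring carrying fluorine separates from neither of the other two, so no order can be set among compounds 1, 2 and 3. Nothing at hand bears on why these groups read alike.

As far as these compounds go, it remains open whether any other kind of group on this carbonyl carbon, such as an amine, a carboxylic acid or a longer chain, would step beyond the scatter in this assay. From the compounds shown here alone, how a plain phenyl group would compare with 4-fluorophenyl also remains open.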